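From 4-fluorobenzyl to 2-fluorobenzyl on compound 1

The source may hold more compounds than are shown below. What is called first, only, known or untested is meant among the compounds shown, and "the series" means these compounds.

Among the compounds with values here, in a functional assay on MDA-MB-231 cells (Homo sapiens) for cytotoxicity, read by MTT assay, with a stated time of 24 h (a lower number here means a stronger inhibitor, a higher number a weaker inhibitor), compound 1 (`COc1ccc(/C=C2\CN(Cc3cn(Cc4ccc(F)cc4)nn3)C/C(=C\c3ccc(OC)cc3)C2=O)cc1`) gives 70700 nM, the higher of the two numbers available, which makes it the weaker of the two compounds measured so far. In this assay, compound 2 (`O=C1/C(=C/c2ccccc2F)CN(Cc2cn(Cc3ccc(F)cc3)nn2)C/C1=C\c1ccccc1F`) gives 10000 nM, a number lower by more than the usual scatter. Both carry the 4-fluorobenzyl group and differ elsewhere, so their gap says nothing about that group.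

Compound 3 (`COc1ccc(/C=C2\CN(Cc3cn(Cc4ccccc4F)nn3)C/C(=C\c3ccc(OC)cc3)C2=O)cc1`) has the same atoms as compound 1, joined differently: 2-fluorophenyl in place of 4-fluorophenyl on a saturated chain carbon bound to an aromatic nitrogen. The change is 4-fluorobenzyl to 2-fluorobenzyl, on a saturated chain carbon bound to an aromatic nitrogen, and the core of compound 1 stays as it is.

Within the data shown here, no measured pair shows this change on its own in this assay, so the expectation is anchored only on compound 1 at 70700 nM. The step of a 1.3-fold lower number from compound 1 to compound 3 (0.11 log units; within the scatter) is expected to stay within the scatter, with no clear direction. For compound 3 the estimated value is 55000 nM, with an expected range from 20000 nM to 130000 nM.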

Compound 3, half-maximal inhibitory concentration: 67200 nM
Compound 3: the middle estimate sits 1.2-fold (0.09 log units) below what was measured; the range from low to high includes it.
By their numbers in this assay, from the lowest: compound 2; then compounds 3 and 1 (each within the scatter of the next).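

In this assay, exchanging 4-fluorobenzyl for 2-fluorobenzyl on the core of compound 1 gives a 1.1-fold lower number from compound 1 to compound 3 (0.02 log units; within the scatter). Within the data shown here, this is the first direct reading of the change at this place, and on this core the two groups cannot be told apart in this cytotoxicity read-out, so the place of the fluorine on the benzyl ring does not register here. Compound 1 and compound 2 both carry 4-fluorobenzyl and differ elsewhere, so they could not show this, and no measured property of either group is available to explain the result.

On these data alone, whether the exchange reads the same way on the core of compound 2, where the numbers are already lower, remains open, as one pair on one core cannot show how general this is. The compounds shown also leave open how this place, on a saturated chain carbon bound to an aromatic nitrogen, would respond to a group of another kind, such as an amine, a carboxylic acid or a longer alkyl chain in place of the fluorophenyl ring.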